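The source may report more compounds than this note shows. Statements on the series, on what has been measured and on what is new or still open speak of the compounds shown alone.

Compound 1 `CC(=O)Oc1ccc(/C=C/c2ccc3ccccc3c2)cc1`: > 5000 nM (a limit of the assay, not a number)
Compound 2 `COc1cccc(/C=C\c2ccc3ccccc3c2)c1`: 1920 nM

All readings come from a functional assay on A549 cells (Homo sapiens) for inhibition; a lower number here means a stronger inhibitor, a higher number a weaker inhibitor. Among the measured compounds shown here, compound 2 holds the only actual number so far, 1920 nM. The other reading, that of compound 1, is a limit: the limit of > 5000 nM in this assay, at which 1 of the 2 values shown sits.

Next in this assay is compound 3 `COc1cc(/C=C\c2ccc3ccccc3c2)ccc1F`, which keeps compound 2 intact apart from one change: fluoro in place of hydrogen on an aromatic carbon. Fluoro replaces hydrogen on an aromatic carbon, ortho to the methoxy group and para to the large group.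

For the measured compounds named here, no measured pair isolates a change of this kind, so the expectation rests on the small size of the change alone. No clear direction is expected. The estimated step, a 1.1-fold lower number from compound 2 to compound 3 (0.03 log units; within the scatter), is expected to stay within the scatter. The expected value for compound 3 is 1800 nM, with an estimated range of 500 nM to 5000 nM.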

Compound 3, half-maximal inhibitory concentration: 450 nM
Compound 3: middle estimate off by 4.0-fold (0.60 log units), on the high side, outside the stated range (below it).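

Among the compounds shown here, the aromatic carbon ortho to a methoxy group and para to a large group is the first place where a single change can be read: in this assay, fluoro in place of hydrogen gives a 4.3-fold lower number from compound 2 to compound 3 (0.63 log units; beyond the scatter) as a modest step beyond the scatter. This carbon therefore does not tolerate substitution silently, since one fluorine atom is enough to shift the reading in the direction of stronger inhibition. Nothing among the data shown accounts for this step.

Fluoro is the only group shown at this carbon, so it remains open whether chloro, hydroxyl or an amine there would shift the reading the same way, or by as much. For the compounds shown here, the reading of compound 1, > 5000 nM, is a limit of the assay and not a number, so no step to it can be read.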